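The compounds below may be only part of what the source reports. "The series", "measured", "known", "first", "only" and "open" are said of these compounds alone.

Three compounds share one core and differ only in the side chain. Compound 1 `O=S(=O)(NCCNc1nccc(-c2c(-c3cccc(F)c3)nc3sccn23)n1)c1ccc(F)cc1` gives 9450 nM in a functional assay on SK-MEL-28 cells (Homo sapiens) for cytotoxicity, read by MTT assay; on this read-out lower numbers stand for stronger inhibition and higher numbers for weaker inhibition. Compound 3 `Cc1ccc(C(=O)NCCNc2nccc(-c3c(-c4cccc(F)c4)nc4sccn34)n2)cc1` gives 18800 nM in this assay, the higher of the two numbers in the set, with compound 1 nearest, as the step of a 2.0-fold higher number from compound 1 to compound 3 (0.30 log units; within the scatter) shows. Compound 2 `O=C(NCCCNc1nccc(-c2c(-c3cccc(F)c3)nc3sccn23)n1)c1ccc(Cl)cc1` reaches only a limit of the assay, > 20000 nM, in this assay, which is the limit of > 20000 nM in this assay, at which 1 of the 3 values shown sits. The step of an at least 1.0-fold lower number from compound 2 to compound 3 (0.02 log units; that floor lies within the scatter) therefore rests on that limit as well.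

Compound 4 `O=C(NCCCNc1nccc(-c2c(-c3cccc(F)c3)nc3sccn23)n1)c1ccc(F)cc1` is not yet measured. It differs from compound 3 by (((4-fluorophenyl)carbonyl)amino)methyl in place of ((4-methylphenyl)carbonyl)amino on a saturated chain carbon, two bonds along the chain from a nitrogen on an aromatic ring. In its chain part this is the reverse of the measured step of an at least 1.0-fold lower number from compound 2 to compound 3 (0.02 log units; that floor lies within the scatter), and compound 4 differs from compound 2 only in the halogen on the aryl carbonyl. The steps of an at least 2.1-fold higher number from compound 1 to compound 2 (0.32 log units; beyond the scatter) and a 2.0-fold higher number from compound 1 to compound 3 (0.30 log units; within the scatter) both went to higher numbers on going from the sulfonyl to a carbonyl. The expected step of a 1.2-fold higher number from compound 3 to compound 4 (0.07 log units; within the scatter) is therefore small, towards a higher number, and not beyond the scatter. Compound 4 is expected to give about 22000 nM in this assay, within 10000 nM to 50000 nM, and may well come out only as a limit.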

Compound 4, half-maximal inhibitory concentration: > 20000 nM
Compound 4 gave a limit, no number; the forecaster's own chance of this, stated with the estimate: 55%; the middle value lies beyond the limit too.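

In this assay, compound 4 gives a limit of the assay and not a number, as compound 2 does: the limit of > 20000 nM in this assay, at which 2 of the 4 values shown sit.

The step of an at least 2.1-fold higher number from compound 1 to compound 4 (0.32 log units; beyond the scatter) lies beyond the scatter with the 4-fluorophenyl group kept, so the move away from compound 1 to a higher number does not need the chloro group of compound 2. The step of an at least 1.0-fold higher number from compound 3 to compound 4 (0.02 log units; that floor lies within the scatter) has a floor within the scatter, and the step between the two limits cannot be read, so fluoro in place of chloro on an aromatic carbon shows no readable effect here.

Compound 1 and compound 4 differ in both the carbonyl and the chain carbon, which leaves open which of the two carries the step. Also open, on these data alone, is whether an amine or a carboxylic acid on this chain would give lower numbers.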